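A few compounds are considered here, and "the series" means these few. Any claim that something is new, unique, unknown or untested is made for them only; others in the source may bear on it.

Measured so far in a functional assay on PC-3 cells (Homo sapiens) for antiproliferative activity, read by MTT assay, with a stated time of 72 h; a higher number here means a weaker inhibitor, a lower number a stronger inhibitor:
- Compound 1 `CN1CCN(C/C=C/C(=O)Nc2cc3c(N4CCc5ccccc54)ncnc3cc2O[C@@H]2CCOC2)CC1`: 4210 nM
- Compound 2 `O=C(/C=C/CN1CCC(CO)CC1)Nc1cc2c(N3CCc4ccccc43)ncnc2cc1O[C@@H]1CCOC1`: 3310 nM
- Compound 3 `CN1CCN(C/C=C/C(=O)Nc2cc3c(N4CCCc5ccccc54)ncnc3cc2O[C@@H]2CCOC2)CC1`: 9450 nM

Compound 4 `O=C(/C=C/CN1CCC(CO)CC1)Nc1cc2c(N3CCCc4ccccc43)ncnc2cc1O[C@@H]1CCOC1` remains to be measured in this assay.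

The change from compound 3 to compound 4 is 4-(hydroxymethyl)piperidin-1-yl in place of 4-methylpiperazin-1-yl on a saturated chain carbon bound to a double-bonded chain carbon. The same change has already been made once, from compound 1 to compound 2: 4-(hydroxymethyl)piperidin-1-yl in place of 4-methylpiperazin-1-yl on a saturated chain carbon bound to a double-bonded chain carbon. There it gave a 1.3-fold lower number from compound 1 to compound 2 (0.10 log units; within the scatter). The place line of both changes is identical, so the two are the same change carried out on different cores.

The cores differ as follows: 1,2,3,4-tetrahydroquinolin-1-yl in place of 2,3-dihydro-1H-indol-1-yl on an aromatic carbon. That change alone gave a 2.2-fold higher number from compound 1 to compound 3 (0.35 log units; beyond the scatter), leaving compound 3 as the highest of the three numbers; compound 2 stands furthest from it.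

With a single earlier instance of the change, the expectation for compound 4 rests on the step from compound 1 to compound 2 alone. A step of about the same size, a 1.3-fold lower number from compound 3 to compound 4 (0.11 log units; within the scatter), is estimated from compound 3 to compound 4, which would keep compound 4 within the scatter of compound 3 because a 1.3-fold lower number from compound 1 to compound 2 (0.10 log units; within the scatter) was itself within the scatter. Compound 4 is therefore expected to give about 7400 nM in this assay.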

Compound 4, half-maximal inhibitory concentration: 5460 nM
Beside the measured number, compound 4's estimate is 1.4-fold (0.13 log units) above it; measured number inside the range.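

In this assay, replacing 4-methylpiperazin-1-yl with 4-(hydroxymethyl)piperidin-1-yl on the core of compound 3 gives a 1.7-fold lower number from compound 3 to compound 4 (0.24 log units; within the scatter), and the change reads alike on both cores: the same change on two cores in this assay, a 1.3-fold lower number (0.10 log units; within the scatter) from compound 1 to compound 2 and a 1.7-fold lower number (0.24 log units; within the scatter) from compound 3 to compound 4, 1.4-fold (0.13 log units) apart, within the scatter of two such steps. For the compounds shown here, the 1,2,3,4-tetrahydroquinolin-1-yl for 2,3-dihydro-1H-indol-1-yl change, read with 4-(hydroxymethyl)piperidin-1-yl in place, gives a 1.6-fold higher number from compound 2 to compound 4 (0.22 log units; within the scatter), and this step also agrees with its earlier counterpart, although only that earlier step lies beyond the scatter: the same change on two cores in this assay, a 2.2-fold higher number (0.35 log units; beyond the scatter) from compound 1 to compound 3 and a 1.6-fold higher number (0.22 log units; within the scatter) from compound 2 to compound 4, 1.4-fold (0.13 log units) apart, within the scatter of two such steps. Across these four compounds, the two changes show no measurable dependence on each other, but the side-chain change is within the scatter on both cores, so no real effect of it is shown, and two cores do not establish transfer to others.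

As far as these compounds go, it remains open whether a morpholin-4-yl or dimethylamino group on the same saturated chain carbon would behave alike on both cores. From the compounds shown here alone, the effect of a carboxylic acid in place of the hydroxymethyl group also remains open.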